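From 3-bromophenyl to 2-fluorophenyl on a shared core

A few compounds are considered here, and "the series" means these few. Any claim that something is new, unique, unknown or untested is made for them only; others in the source may bear on it.

Measured in a functional assay on HepG2 cells (Homo sapiens) for antiproliferative activity, read by MTT assay, with a stated time of 48 h; a lower number here means a stronger inhibitor, a higher number a weaker inhibitor:
- compound 1 `CC(=O)N1N=C(c2ccc3ccccc3c2)OC1c1cccc(Br)c1`: 1.68 ug/mL
- compound 2 `CC(=O)N1N=C(c2ccc3ccccc3c2)OC1c1ccc(Br)cc1`: 2.08 ug/mL
- compound 3 `CC(=O)N1N=C(c2ccc3ccccc3c2)OC1c1ccccc1Cl`: 4.32 ug/mL

Compound 1 stands at the low end of these three numbers, but it has company there. The nearest comparison shows a 1.2-fold higher number from compound 1 to compound 2 (0.09 log units; within the scatter), so 3-bromophenyl and 4-bromophenyl cannot be told apart in this assay. The furthest comparison shows a 2.6-fold higher number from compound 1 to compound 3 (0.41 log units; beyond the scatter).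

Compound 4 `CC(=O)N1N=C(c2ccc3ccccc3c2)OC1c1ccccc1F` has not yet been measured. It carries 2-fluorophenyl in place of 3-bromophenyl on a saturated ring carbon.

Among the compounds with values here, the closest guide is compound 3, the only measured compound with a 2-substituted phenyl. Its two steps are both modest: a 2.6-fold higher number from compound 1 to compound 3 (0.41 log units; beyond the scatter) and a 2.1-fold higher number from compound 2 to compound 3 (0.32 log units; beyond the scatter). The second lies only just beyond the scatter. Within the data shown here, no measured step exchanges 2-chlorophenyl for 2-fluorophenyl, so the data do not show what that swap does. Compound 4 is therefore expected to sit near compound 3 at 4.32 ug/mL, with a wide margin on either side.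

The step expected in this assay is a 2.7-fold higher number from compound 1 to compound 4 (0.43 log units; beyond the scatter), a modest one toward a higher number. The estimated value for compound 4 is 4.5 ug/mL, with an expected range from 2.2 ug/mL to 9 ug/mL.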

Compound 4, half-maximal inhibitory concentration: 3.36 ug/mL
Beside the measured number, compound 4's estimate is 1.3-fold (0.13 log units) above it, within the range that was stated.
By their numbers in this assay, from the lowest: compounds 1, 2, 4 and 3 (each within the scatter of the next, the first and the last beyond it).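

In this assay, within the data shown here, the first measured exchange of chloro for fluoro on an aromatic carbon gives a 1.3-fold lower number from compound 3 to compound 4 (0.11 log units; within the scatter) and so shows no difference that can be read between the 2-chlorophenyl and 2-fluorophenyl compounds. The 2-fluorophenyl group also stays within the scatter of both bromophenyl groups, with a 2.0-fold higher number from compound 1 to compound 4 (0.30 log units; within the scatter) and a 1.6-fold higher number from compound 2 to compound 4 (0.21 log units; within the scatter) on the shared core, whereas compound 3 lies beyond the scatter of both; the separation seen earlier for the 2-chlorophenyl compound therefore does not extend clearly to its fluoro counterpart, and the four compounds form a chain of close neighbours in which only compound 3 stands apart from compounds 1 and 2. Nothing measured alongside these numbers speaks to what lies behind these small steps.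

From compound 1 to compound 4, both the halogen and its place on the phenyl ring change, so the compounds shown do not separate the share of each. All four carry a single halogen on that phenyl ring, which leaves open how a methoxy group, an amine or a carboxylic acid there would fare.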